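The compounds below may be only part of what the source reports. "The series", "measured", "known", "first", "only" and "open" are said of these compounds alone.

Measured compounds in an ADME assay on HFF cells (Homo sapiens) for cytotoxicity, with a stated time of 8 days; a higher number here means that more compound is tolerated, a lower number that less compound is tolerated:
compound 1 `CCCCCCCCOc1nc(N)nc2c1ncn2/C=C1/CC1(CO)CO` gives > 300000 nM, a limit of the assay.
compound 2 `Nc1nc(NC2CCCCC2)c2ncn(/C=C3/CC3(CO)CO)c2n1` gives > 300000 nM, a limit of the assay.
compound 3 `CCCNc1nc(N)nc2c1ncn2/C=C1/CC1(CO)CO` gives > 300000 nM, a limit of the assay.

Compound 3 therefore stands at the same limit as the other two measured compounds; no number is known for it, only the limit of > 300000 nM in this assay, at which 3 of the 3 values shown sit, at which all three values sit. The steps a step that the two limits leave unreadable from compound 1 to compound 2, a step that the two limits leave unreadable from compound 1 to compound 3 and a step that the two limits leave unreadable from compound 2 to compound 3 cannot be sized, since both ends of each lie at the limit.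

Compound 4 `CC(C)CNc1nc(N)nc2c1ncn2/C=C1/CC1(CO)CO` differs from compound 3 by methyl in place of hydrogen on a saturated chain carbon bound to two saturated chain carbons, that is propylamino to isobutylamino on the aromatic carbon. The step that bears on it is the one from the cyclohexyl to the propyl substituent on that nitrogen, and it is unreadable. For the measured compounds named here, nothing among the measured compounds suggests that a change of this kind brings the value down into the readable range, so compound 4 is expected to remain at the limit too, with an expected step of a number no higher from compound 3 to compound 4 (the limit leaves the size open). The estimate for compound 4 in this assay is 300000 nM, between 100000 nM and 1000000 nM, most likely reported again only as a limit.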

Compound 4, half-maximal cytotoxic concentration: > 300000 nM
Compound 4: a limit, no number; the forecaster's own chance of this, stated with the estimate: 85%; the middle value lies on the limit itself.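

In this assay compound 4 gives > 300000 nM, a limit of the assay, so no new step among compound 1, compound 2, compound 3 and compound 4 can be read: the limit of > 300000 nM in this assay, at which 4 of the 4 values shown sit.

The compounds shown leave open whether the substituents differ in cytotoxicity at all, as no compound has a readable number.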